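A few compounds are considered here, and "the series" means these few. Any claim that something is new, unique, unknown or untested is made for them only; others in the source may bear on it.

Working notes on the series.

Three compounds have numbers in an assay on THP-1 cells for antagonist activity at Toll-like receptor 8 (Homo sapiens); a lower number here means a stronger inhibitor, a higher number a weaker inhibitor. Compound 1, `Cc1cc(-c2cnc(OCC34CCC(N)(CC3)CC4)c(C)c2)c2cnn(C)c2n1`, gives 2 nM; compound 3, `Cc1cc(-c2nn(C)c3nc(N)ncc23)cnc1OCC12CCC(N)(CC1)CC2`, gives 1 nM. Compound 2, `Cn1nc(-c2ccc(OCC34CCC(O)(CC3)CC4)c(F)c2)c2cnc(N)nc21`, gives 75 nM and so stands highest of the three: its gaps to compound 1 and to compound 3 both lie beyond the scatter. Going by the values given here, compound 1 and compound 3 share a saturated bicyclic group bearing an amine on the chain ether, whereas compound 2 carries a hydroxyl at the corresponding position of the same bicyclic group; no single-point step between the measured compounds exists, so nothing more than this comparison can be drawn.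

Compound 4, `Cn1nc(-c2ccc(OC[C@H]3CC[C@@H](N)CC3)c(F)c2)c2cnc(N)nc21`, is not yet measured. It differs from compound 2 in one place: a group of 7 heavy atoms (6 carbon, 1 nitrogen; one six-membered non-aromatic ring of carbon only) in place of a group of 9 heavy atoms (8 carbon, 1 oxygen; 2 six-membered non-aromatic rings of carbon only), on a saturated chain carbon bound to an oxygen on an aromatic ring. The change brings in an amine where compound 2 has a hydroxyl, which is the feature shared by compound 1 at 2 nM and compound 3 at 1 nM. A step toward a lower number is therefore expected, though a smaller ring replaces the bicyclic one, so the full gain is uncertain. The expected step is a 6.3-fold lower number from compound 2 to compound 4 (0.80 log units; beyond the scatter), and compound 4 is estimated at 12 nM, between 3 nM and 50 nM.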

Compound 4, half-maximal inhibitory concentration: 20 nM
Estimate against measurement, compound 4: 1.7-fold (0.22 log units) below; low and high end bracket the measured number.
By their numbers in this assay, from the lowest: compounds 3 and 1 (each within the scatter of the next); then compound 4; then compound 2.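

In this assay, going by these compounds alone, the change on a saturated chain carbon bound to an oxygen on an aromatic ring gives a 3.8-fold lower number from compound 2 to compound 4 (0.57 log units; beyond the scatter) and so shows that the number moves with the group held at this place, which the earlier compounds, linked by no single-place step, could not show. The step is a combined one: 4-aminocyclohexyl brings in the amine and also replaces the two six-membered non-aromatic rings of carbon only with one, so the two parts of the change stay unseparated. No measured evidence on the origin of this step is at hand.

On these data alone, the shares of the amine and the ring remain open; the core of compound 2 with an amine on its bicyclic group, or with a hydroxyl on a single cyclohexyl ring, would divide them. Also open, as far as these compounds go, are the other stereoisomer of 4-aminocyclohexyl and how a carboxylic acid would read at this place.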